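Swapping a branched chain for a ring on the pyridine carbon

This account rests on a few compounds, and the source may have more. Where it says the series, first, only, none or still open, it means among the compounds named here.

Measured so far:
Compound 1: `CC(C(=O)NCc1ccc(C(F)(F)F)nc1Br)c1ccc(NS(C)(=O)=O)c(F)c1`, 169 nM
Compound 2: `CCCCCCc1nc(C(F)(F)F)ccc1CNC(=O)C(C)c1ccc(NS(C)(=O)=O)c(F)c1`, 1.6 nM
Compound 3: `CC(C(=O)NCc1ccc(C(F)(F)F)nc1CCC(C)(C)C)c1ccc(NS(C)(=O)=O)c(F)c1`, 0.6 nM

These were tested in an assay on CHO cells for antagonist activity at transient receptor potential cation channel subfamily V member 1 (Homo sapiens), read by FLIPR and calcium flux; a higher number here means a weaker inhibitor, a lower number a stronger inhibitor. Compound 3 gives the lowest number of the three, beyond the scatter from both others; compound 2 comes nearest, compound 1 furthest. The measured steps are a 110-fold lower number from compound 1 to compound 2 (2.02 log units; beyond the scatter), a 280-fold lower number from compound 1 to compound 3 (2.45 log units; beyond the scatter) and a 2.7-fold lower number from compound 2 to compound 3 (0.43 log units; beyond the scatter). In each case a larger carbon group in place of bromo brought a large gain, and the change between the two large groups mattered only modestly.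

Compound 4 is `CCC1CCC(c2nc(C(F)(F)F)ccc2CNC(=O)C(C)c2ccc(NS(C)(=O)=O)c(F)c2)CC1`. The change is 4-ethylcyclohexyl in place of 3,3-dimethylbutyl on an aromatic carbon. The earlier steps shown here show that a large carbon group at this position is what gives most of the potency, while its exact shape shifts the number only modestly, as seen from compound 2 to compound 3. Compound 4 is therefore expected to stay close to compound 3, with a small step at most: a 1.7-fold higher number from compound 3 to compound 4 (0.22 log units; within the scatter). The estimate for compound 4 is 1 nM, in the range 0.3 nM to 4 nM.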

Compound 4, inhibition constant: 0.3 nM
The estimate for compound 4 lay 3.3-fold (0.52 log units) above the measured number; the measured number falls inside the stated range.
By their numbers in this assay, from the lowest: compounds 4 and 3 (each within the scatter of the next); then compound 2; then compound 1.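

For the compounds shown here, compound 4 is the first compound here with a ring, rather than an open chain, on this pyridine carbon, and in this assay the ring and the branched chain cannot be told apart (a 2.0-fold lower number from compound 3 to compound 4 (0.30 log units; within the scatter)). So an open chain is not needed for this level of activity, and the 4-ethylcyclohexyl group also keeps the large gain over bromo (a 560-fold lower number from compound 1 to compound 4 (2.75 log units; beyond the scatter)), with a modest gain over hexyl that lies beyond the scatter (a 5.3-fold lower number from compound 2 to compound 4 (0.73 log units; beyond the scatter)). Nothing measured here explains why these carbon groups differ so little from one another.

Going by these compounds, whether the ethyl group matters remains open, since plain cyclohexyl would be needed to test it. On these data alone, it is also open whether this position would accept a phenyl ring, or a cyclohexyl ring carrying an amine or a carboxylic acid.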